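Swapping a Phenoxy for Dimethylamino on a Shared Core

The source may hold more compounds than are shown below. What is called first, only, known or untested is meant among the compounds shown, and "the series" means these compounds.

Two compounds on a shared core have numbers in a functional assay on MCF7 cells (Homo sapiens) for cytotoxicity, read by MTT assay, with a stated time of 72 h; on this read-out lower numbers stand for stronger inhibition and higher numbers for weaker inhibition. Compound 1 `N[C@H]1CC[C@H](Nc2c(C(=O)NCc3ccc(F)cc3)nc(N3CCCCC3)c3cccnc23)CC1` gives 5000 nM. Compound 2 `N[C@H]1CC[C@H](Nc2c(C(=O)NCc3ccc(Oc4ccccc4)cc3)nc(Br)c3cccnc23)CC1` gives 7900 nM, the higher of the two numbers, although its gap to compound 1 lies within the usual scatter, so neither can be called the weaker one. Compound 3 `N[C@H]1CC[C@H](NC(=O)c2nc(Br)c3cccnc3c2NCc2ccc(F)cc2)CC1` has no result in this assay, reported as "not determined" (no result reported). Compound 4 `CN(C)c1ccc(CNC(=O)c2nc(Br)c3cccnc3c2N[C@H]2CC[C@H](N)CC2)cc1` has not yet been measured. It differs from compound 2 in one place: dimethylamino in place of phenoxy on an aromatic carbon. Among the measured compounds shown here, no step between measured compounds bears on this change, so the number is expected to shift little, if at all, beyond the scatter in either direction. Compound 4 is expected to give about 6000 nM, plausibly between 2000 nM and 20000 nM. The expected step is a 1.3-fold lower number from compound 2 to compound 4 (0.12 log units; within the scatter).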

Compound 4, half-maximal inhibitory concentration: 5000 nM
The estimate for compound 4 lay 1.2-fold (0.08 log units) above the measured number, within the range that was stated.
By their numbers in this assay, from the lowest: compounds 1, 4 and 2 (each within the scatter of the next).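

In this assay, putting dimethylamino in place of phenoxy on this aromatic carbon gives a 1.6-fold lower number from compound 2 to compound 4 (0.20 log units; within the scatter). Among the compounds shown here, this is the first direct look at this position, and it shows that the ring of phenoxy can give way to a group with no ring while compound 2 and compound 4 remain indistinguishable in this read-out. Nothing measured here offers an explanation for this result.

As far as these compounds go, it remains open whether a carboxylic acid or a primary amine on the same aromatic carbon would move the number beyond the scatter.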